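The source may hold more compounds than are shown below. What is called first, only, known or untested is meant among the compounds shown, and "the series" means these compounds.

Working notes on the series. In an assay on CHO cells for displacement of a labelled ligand from 5-hydroxytryptamine receptor 1B (Homo sapiens) (on this read-out lower numbers stand for stronger inhibition and higher numbers for weaker inhibition), compound 1 `CC(=O)Nc1ccc([C@H](C)NCC2CCN(CCCc3c[nH]c4ccc(-n5cnnc5)cc34)CC2)cc1` gives 9.3 nM, compound 3 `CN(CC1CCN(CCCc2c[nH]c3ccc(-n4cnnc4)cc23)CC1)C(=O)Nc1ccccc1` gives 6.2 nM, and compound 2 `CC(C)=CCCN(C)C1CCN(CCCc2c[nH]c3ccc(-n4cnnc4)cc23)CC1` gives 24 nM. Compound 2 stands highest of the three numbers, beyond the scatter from both compound 1 and compound 3. Compound 4 `c1cncc(CNC2CCN(CCCc3c[nH]c4ccc(-n5cnnc5)cc34)CC2)c1` has not yet been measured in this assay; relative to compound 2 it carries ((pyridin-3-yl)methyl)amino in place of methyl(4-methylpent-3-en-1-yl)amino on a saturated ring carbon. Compound 1 at 9.3 nM and compound 3 at 6.2 nM, whose side chains also include a hydrogen-bond donor and an aromatic ring, both sit lower than compound 2. A step of a 2.4-fold lower number from compound 2 to compound 4 (0.38 log units; beyond the scatter) is therefore expected, downward and just beyond the scatter. Compound 4 is estimated at 10 nM, with a range of 4 nM to 25 nM.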

Compound 4, half-maximal inhibitory concentration: 140 nM
For compound 4 the middle estimate is 14-fold (1.15 log units) below the measured one; measured number above the stated range.
By their numbers in this assay, from the lowest: compounds 3 and 1 (each within the scatter of the next); then compound 2; then compound 4.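

On the saturated ring carbon, ((pyridin-3-yl)methyl)amino in place of methyl(4-methylpent-3-en-1-yl)amino gives, in this assay, a 5.8-fold higher number from compound 2 to compound 4 (0.77 log units; beyond the scatter). At this position, then, an entering aromatic ring and hydrogen-bond donor do not by themselves bring a lower number, even with the heavy-atom count unchanged. No measurement at hand accounts for the step. Still open, on these data alone, is which part of the change carries the step: the pyridine nitrogen, the amine hydrogen or the departing alkenyl chain. Benzylamino or methyl((pyridin-3-yl)methyl)amino on the same carbon would separate these.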